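Notes on the step from compound 2 to compound 3

The compounds below may be only part of what the source reports. "The series", "measured", "known", "first", "only" and "open" are said of these compounds alone.

compound 1 `O=C1/C(=C\c2c(Cl)cccc2Cl)c2ccccc2N1c1c(Cl)cccc1Cl`: > 100 ug/mL
compound 2 `CN(C)c1ccc(/C=C2\C(=O)N(c3c(Cl)cccc3Cl)c3ccccc32)cc1`: > 100 ug/mL

In a functional assay on MCF7 cells (Homo sapiens) for cytotoxicity, read by MTT assay, with a stated time of 72 h (a lower number here means that less compound is needed, a higher number that more compound is needed for the effect), compound 1 gives only a limit, > 100 ug/mL. Compound 2 also gives only a limit in this assay, > 100 ug/mL. The step that the two limits leave unreadable from compound 1 to compound 2 is thus unreadable, and the limit of > 100 ug/mL in this assay, at which 2 of the 2 values shown sit, is all that the two values show. Compound 3 `O=C1/C(=C\c2cccc(Br)c2)c2ccccc2N1c1c(Cl)cccc1Cl` differs from compound 2 by 3-bromophenyl in place of 4-(dimethylamino)phenyl on a double-bonded chain carbon bound to a double-bonded ring carbon. Going by the values given here, no measured step with a readable size bears on this change, so no direction beyond the scatter can be expected in this assay. Compound 3 is expected to sit near the same limit, estimated at about 100 ug/mL, with a range from 40 ug/mL to 250 ug/mL. The implied step a number no higher from compound 2 to compound 3 (the limit leaves the size open) is expected to be small.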

Compound 3, concentration for half-maximal effect: 5 ug/mL
Beside the measured number, compound 3's estimate is 20-fold (1.30 log units) above it; measured number below the stated range.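

In this assay, 3-bromophenyl on a double-bonded chain carbon bound to a double-bonded ring carbon gives an at least 20-fold lower number from compound 2 to compound 3 (1.30 log units; beyond the scatter) and an at least 20-fold lower number from compound 1 to compound 3 (1.30 log units; beyond the scatter). This place in the series therefore responds to the group it carries, which the step between compound 1 and compound 2 could not show, as that step cannot be read. Only compound 3 gives a number rather than a limit: the limit of > 100 ug/mL in this assay, at which 2 of the 3 values shown sit.

On these data alone, it remains open whether the bromine is needed for this number. Unsubstituted phenyl, or methoxy or chlorine in place of the bromine, would test that.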